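The compounds below may be only part of what the source reports. "The series", "measured", "known", "first", "only" and "open" are said of these compounds alone.

Measured compounds and values:
- compound 1 `COc1ccccc1C1C(C#N)=C(N)N(c2ccc(S(N)(=O)=O)cc2)C2=C1C(=O)CCC2`: 0%
- compound 2 `COc1cc(CC2C(C#N)=C(N)N(c3ccc(S(N)(=O)=O)cc3)C3=C2C(=O)CCC3)ccc1O`: 90%
- compound 3 `N#CC1=C(N)N(c2ccc(S(N)(=O)=O)cc2)C2=C(C(=O)CCC2)C1c1ccc([N+](=O)[O-])cc1`: 95%

In a functional assay on Ehrlich cells (Mus musculus) for antiproliferative activity, read by trypan blue exclusion, with a stated time of 2 h, tested at 50 ug/mL (a higher number here means a stronger effect of the compound at the concentration tested, a lower number a weaker effect), compound 2 gives 90%, the second highest of the three numbers. Its nearest neighbour is compound 3, where the step of a number 5 percentage points higher from compound 2 to compound 3 (within the scatter) lies within the scatter, so the two cannot be ranked against each other. Compound 1, with 0%, lies far below, as the step of a number 90 percentage points higher from compound 1 to compound 2 (beyond the scatter) shows.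

Compound 4 `N#CC1=C(N)N(c2ccc(S(N)(=O)=O)cc2)C2=C(C(=O)CCC2)C1c1ccco1` is not yet measured. It differs from compound 2 in a single place: furan-2-yl in place of 4-hydroxy-3-methoxybenzyl on a saturated ring carbon.

All three measured steps swap the group on that same saturated ring carbon. Two of them, a number 90 percentage points higher from compound 1 to compound 2 (beyond the scatter) and a number 95 percentage points higher from compound 1 to compound 3 (beyond the scatter), were large, while a number 5 percentage points higher from compound 2 to compound 3 (within the scatter) stayed within the scatter. The position therefore matters greatly in this assay, yet nothing measured carries furan-2-yl, so the direction for compound 4 is open. Compound 4 is estimated at 65% (range 20% to 95%), which means an expected step of a number 25 percentage points lower from compound 2 to compound 4 (beyond the scatter).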

Compound 4, a percentage reported as activity, at one concentration (the size of the read-out at that concentration, not a potency): 5%
The estimate for compound 4 lay 60 percentage points above the measured number, outside the stated range (below it).
By their numbers in this assay, from the lowest: compounds 1 and 4 (each within the scatter of the next); then compounds 2 and 3 (each within the scatter of the next).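

Furan-2-yl on this saturated ring carbon does not keep the high reading in this assay: the drops in a number 85 percentage points lower from compound 2 to compound 4 (beyond the scatter) and a number 90 percentage points lower from compound 3 to compound 4 (beyond the scatter) are both large, while a number 5 percentage points higher from compound 1 to compound 4 (within the scatter) stays within the scatter. The low level is therefore not peculiar to 2-methoxyphenyl. All four compounds carry an aromatic ring here, and having such a ring at this position does not by itself secure a high number, as compounds 1 and 4 show. No measurement given here explains why these groups divide in this way.

The 4-hydroxy-3-methoxybenzyl and furan-2-yl groups differ in ring size, heavy-atom count and hydrogen-bond donors all at once, so these features cannot be separated. Going by these compounds, how unsubstituted phenyl, pyridin-3-yl or an open butyl chain would read on this carbon remains open.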